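The source may report more compounds than this note shows. Statements on the series, on what has been measured and on what is new or still open speak of the compounds shown alone.

Of the compounds shown here, three have so far been tested in an assay on isolated protein for inhibition of Trypsin (Homo sapiens) (on this read-out higher numbers stand for weaker inhibition and lower numbers for stronger inhibition), and all three results are limits of the assay rather than numbers. Compound 1 `COc1ccc(-n2nc(C(F)(F)F)cc2C(=O)Cc2ccc(-c3ccccc3S(N)(=O)=O)cc2)cc1` gives > 2500 nM, a limit. Compound 2 `Nc1noc2ccc(-n3nc(C(F)(F)F)cc3C(=O)Cc3ccc(N4CCCCC4=O)cc3)cc12` gives > 20000 nM, again only a limit. Compound 3 `CN(C)Cc1ccccc1-c1ccc(CC(=O)c2cc(C(F)(F)F)nn2-c2ccc3onc(N)c3c2)c(F)c1` gives > 4200 nM, also a limit. Compound 2 thus sits at the limit of the limit of > 20000 nM in this assay, at which 1 of the 3 values shown sits, and as the other two values are limits too, no order among the three compounds can be read from these numbers; each of them is simply a weak inhibitor at best.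

Compound 4 `Nc1noc2ccc(-n3nc(C(F)(F)F)cc3C(=O)Cc3ccc(-c4ccccc4S(N)(=O)=O)cc3)cc12` has not yet been measured in this assay. It differs from compound 2 in one place: 2-sulfamoylphenyl in place of 2-oxopiperidin-1-yl on an aromatic carbon. This is the same group that compound 1 carries on the same kind of position. Among the compounds with values here, no two measured compounds differ in a single place, so there is no measured step to lean on. Compound 1, which already carries the entering group, shows only the limit of the limit of > 2500 nM in this assay, at which 1 of the 3 values shown sits. The step from compound 2 to compound 4 is expected to be small or none beyond the scatter, with at most a slight lean towards stronger inhibition an at least 2.0-fold lower number from compound 2 to compound 4 (0.30 log units; that floor lies within the scatter). Compound 4 is expected to inhibit at about 10000 nM, in a range from 2000 nM to 50000 nM, and most likely to be reported once more as a limit.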

Compound 4, inhibition constant: > 20000 nM
Compound 4: a limit, no number (the forecaster's own chance of this, stated with the estimate: 80%); middle value at least 2.0-fold (0.30 log units) from the limit.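

In this assay compound 4 gives > 20000 nM, which is a limit and not a number. The results for compound 1 and compound 2 are limits as well, so neither step to compound 4 can be read. The compounds shown leave open whether 2-sulfamoylphenyl in place of 2-oxopiperidin-1-yl changes inhibition at all.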